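Phenyl-Oxazole for Furan on a Hydrazide Carbonyl

The source may report more compounds than this note shows. Statements on the series, on what has been measured and on what is new or still open speak of the compounds shown alone.

Within the data shown here, the three compounds measured so far share one core and differ in the aryl group attached to the hydrazide carbonyl. Compound 1 `CCNC(=O)[C@H]1O[C@@H](n2cnc3c(NNC(=O)c4cccnc4)ncnc32)[C@H](O)[C@@H]1O` carries a pyridin-3-yl group, compound 2 `CCNC(=O)[C@H]1O[C@@H](n2cnc3c(NNC(=O)c4ccc(Br)o4)ncnc32)[C@H](O)[C@@H]1O` a 5-bromofuran-2-yl group, and compound 3 `CCNC(=O)[C@H]1O[C@@H](n2cnc3c(NNC(=O)c4ccco4)nc(Cl)nc32)[C@H](O)[C@@H]1O` a furan-2-yl group. In an assay on CHO cells for displacement of a labelled ligand from adenosine receptor A3 (Homo sapiens) (on this read-out higher numbers stand for weaker inhibition and lower numbers for stronger inhibition), compound 1 gives > 5000 nM, which is a limit of the assay rather than a number. Compound 2 likewise reaches only the limit > 5000 nM. Compound 3 also stands at the limit > 5000 nM. Among the measured compounds shown here, the single step between measured neighbours, a step that the two limits leave unreadable from compound 1 to compound 2, cannot be read because the limit of > 5000 nM in this assay, at which 3 of the 3 values shown sit, holds both of its ends at the same limit.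

Compound 4 `CCNC(=O)[C@H]1O[C@@H](n2cnc3c(NNC(=O)c4cc(-c5ccccc5)on4)nc(Cl)nc32)[C@H](O)[C@@H]1O` is still to be measured; it differs from compound 3 in one place: 5-phenyl-1,2-oxazol-3-yl in place of furan-2-yl on a carbonyl carbon. For the measured compounds named here, no measured step bears on this change, since every value recorded so far is a limit, and the three limits give no direction. The expected step that the limit leaves unreadable from compound 3 to compound 4 in this assay is therefore estimated as none beyond the scatter, with the most likely outcome being another limit. Compound 4 is estimated at 6000 nM, within a range from 1500 nM to 30000 nM.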

Compound 4, inhibition constant: > 5000 nM
Compound 4: a limit, no number; the forecaster's own chance of this, stated with the estimate: 70%; the middle value does not contradict the limit.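

No size can be read for the change from compound 3 to compound 4 in this assay, because both compounds sit at the same limit of the assay rather than at a number: the limit of > 5000 nM in this assay, at which 4 of the 4 values shown sit.

The compounds shown leave open how furan-2-yl and 5-phenyl-1,2-oxazol-3-yl compare on the hydrazide carbonyl, and whether any group there gives a readable number.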